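A few compounds are considered here, and "the series" means these few. Any claim that something is new, unique, unknown or untested is made for them only; others in the source may bear on it.

Compound 3, `COC(=O)C1=C(C)N=C(C)/C(=C(\O)OC)C1c1ccccc1F`, gives 42.7 nM in a functional assay (muscle tissue) with Cavia porcellus as the target (on this read-out higher numbers stand for an effect only at larger amounts of compound and lower numbers for an effect already at smaller amounts), and stands at the low end of the three numbers: compound 1, `COC(=O)C1=C(C)N=C(C)/C(=C(\O)OC)C1c1ccccc1I`, gives 46.8 nM, a difference of a 1.1-fold lower number from compound 1 to compound 3 (0.04 log units; within the scatter), while compound 2, `COC(=O)C1=C(C)N=C(C)/C(=C(\O)OC)C1c1ccc(I)cc1`, gives 22900 nM, so that a 540-fold lower number from compound 2 to compound 3 (2.73 log units; beyond the scatter). Compound 4, `COC(=O)C1=C(C)N=C(C)/C(=C(\O)OC)C1c1cccc(C#N)c1`, differs from compound 3 by 3-cyanophenyl in place of 2-fluorophenyl on a saturated ring carbon. Among the measured compounds shown here, the steps that bear on this change the same aromatic ring: a 490-fold higher number from compound 1 to compound 2 (2.69 log units; beyond the scatter) and a 540-fold lower number from compound 2 to compound 3 (2.73 log units; beyond the scatter) were both large, whereas a 1.1-fold lower number from compound 1 to compound 3 (0.04 log units; within the scatter) stayed within the scatter. Moving the substituent away from the 2-position thus raised the number greatly, though no 3-substituted example has been measured. Compound 4 is therefore expected to give 800 nM, between 100 nM and 8000 nM, an expected step of a 19-fold higher number from compound 3 to compound 4 (1.27 log units; beyond the scatter).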

Compound 4, half-maximal effective concentration: 34.7 nM
Beside the measured number, compound 4's estimate is 23-fold (1.36 log units) above it, outside the stated range (below it).
By their numbers in this assay, from the lowest: compounds 4, 3 and 1 (each within the scatter of the next); then compound 2.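

With 3-cyanophenyl on this saturated ring carbon, the number stays level with the 2-substituted compounds: the step is a 1.2-fold lower number from compound 3 to compound 4 (0.09 log units; within the scatter), and likewise a 1.3-fold lower number from compound 1 to compound 4 (0.13 log units; within the scatter). Compound 2 alone stands apart, with a 660-fold lower number from compound 2 to compound 4 (2.82 log units; beyond the scatter), so leaving the 2-position does not by itself raise the number. No evidence is available to explain this result. As far as these compounds go, whether the high number of compound 2 goes with iodo or with its ring position stays open, and a 4-cyanophenyl group would bear on that. From the compounds shown here alone, how an amine or a carboxylic acid would behave here also remains open.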